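The compounds below may be only part of what the source reports. "The series", "measured", "known", "first", "only" and "open" are said of these compounds alone.

Measured compounds:
- Compound 1, `O=C(CBr)Nc1ccc(C(=O)/C=C/c2ccc(Cl)cc2)cc1`: 59%
- Compound 2, `O=C(CO[N+](=O)[O-])Nc1ccc(C(=O)/C=C/c2ccc(Cl)cc2)cc1`: 67%
- Compound 3, `CC(Br)C(=O)Nc1ccc(C(=O)/C=C/c2ccc(Cl)cc2)cc1`: 54%

In a functional assay on the whole organism (strain albino) for inhibition, with Rattus norvegicus as the target, read by paw edema, with stated times of 30 min and 4 h, at a dose of 100 mg/kg by the oral route (on this read-out lower numbers stand for less inhibition and higher numbers for more inhibition at the one dose given (going by the name of the read-out)), compound 2 gives the highest of the three numbers shown, though the gap to compound 1, a number 8 percentage points higher from compound 1 to compound 2 (within the scatter), is within the scatter, while the gap to compound 3, a number 13 percentage points lower from compound 2 to compound 3 (beyond the scatter), lies beyond it. Compound 4, `CC(=O)c1ccc(OCC(=O)Nc2ccc(C(=O)/C=C/c3ccc(Cl)cc3)cc2)cc1`, has not yet been measured. It differs from compound 2 in one place: 4-acetylphenyl in place of nitro on an oxygen on a saturated carbon.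

Within the data shown here, two measured steps touch the same part of the shared core. The exchange of bromo for nitrooxy on that saturated chain carbon, a number 8 percentage points higher from compound 1 to compound 2 (within the scatter), stayed within the scatter, and the exchange of the whole chain end, a number 13 percentage points lower from compound 2 to compound 3 (beyond the scatter), was modest. Neither step brings in an aromatic ring, so the change to compound 4 is larger than anything measured, and the data give no firm direction for it. A step of about the size already seen, without a clear direction, is therefore expected: a number 7 percentage points lower from compound 2 to compound 4 (within the scatter). For compound 4 the estimated value in this assay is 60%, expected to fall between 45% and 75%.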

Compound 4, a percentage reported as inhibition, in the whole organism at one dose (the size of the read-out at that dose, not a potency): 58%
Compound 4: the middle estimate sits 2 percentage points above what was measured; low and high end bracket the measured number.
By their numbers in this assay, from the lowest: compounds 3, 4, 1 and 2 (each within the scatter of the next, the first and the last beyond it).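

In this assay, among these compounds, the oxygen on the saturated carbon can carry an aromatic ring, which no earlier compound showed: 4-acetylphenyl has 9 heavy atoms against the 3 of nitro, yet the step (a number 9 percentage points lower from compound 2 to compound 4 (within the scatter)) stays within the scatter. The comparison with bromo on the saturated chain carbon reads the same way (a number 1 percentage points lower from compound 1 to compound 4 (within the scatter)), so at this one dose neither nitrooxy nor bromo is needed for a read-out of this size. Nothing available explains this result.

Going by these compounds, it remains open whether the acetyl group on the new ring matters, since a plain phenoxy group would be needed to tell. Also unknown is how an amine such as morpholine or a carboxylic acid would behave on the same saturated chain carbon.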